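Shortening the Chain That Carries the Tetrazole Ring

A few compounds are considered here, and "the series" means these few. Any claim that something is new, unique, unknown or untested is made for them only; others in the source may bear on it.

Compound 2 `CCCc1c(CCCCCc2nnn[nH]2)ccc(C(C)=O)c1O` stands at the top of the two numbers measured in a functional assay on ileum for antagonist activity at cysteinyl leukotriene receptor 1 (Cavia porcellus); on this read-out higher numbers stand for higher potency (the scale is a negative logarithm) and lower numbers for lower potency; compound 2 gives 7.08. Among the compounds with values here, the only other measured compound, compound 1 `CCCc1c(OCCCc2nnn[nH]2)ccc(C(C)=O)c1O`, gives 5.47 in this assay, a gap that lies beyond the usual scatter, so compound 2 is the more potent of the two. Compound 3 `CCCc1c(CCCCc2nnn[nH]2)ccc(C(C)=O)c1O` has not yet been measured in this assay. It differs from compound 2 in one place: 1H-tetrazol-5-yl in place of (1H-tetrazol-5-yl)methyl on a saturated chain carbon, four bonds along the chain from an aromatic carbon. In plain terms, the saturated chain linking the shared core to the tetrazole ring is one carbon shorter. Within the data shown here, no pair of measured compounds shows exactly this change, so its effect must be judged without a directly matching step. The expectation is a moderate loss in this assay, with the step of a number 0.48 log units lower from compound 2 to compound 3 (beyond the scatter) pointing downward and most likely beyond the scatter, though a result within the scatter cannot be ruled out. Compound 3 is therefore estimated at 6.6, with a plausible range from 6 to 7.2.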

Compound 3, negative logarithm of the antagonist equilibrium constant: 6.25
Estimate against measurement, compound 3: 0.35 log units above, and the stated range covers the measured number.
By their numbers in this assay, from the lowest: compound 1; then compound 3; then compound 2.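

In this assay, within the data shown here, the one change here is a shorter saturated chain, and it gives a number 0.83 log units lower from compound 2 to compound 3 (beyond the scatter) on a saturated chain carbon, four bonds along the chain from an aromatic carbon. Among these compounds, the tetrazole ring is the same in both compounds, with the same counts of hydrogen-bond donors and acceptors, so this is the first measured pair in which the length of the chain alone varies, and it shows that the number responds to the removal of a single chain carbon. Nothing measured here accounts for the drop, so the reason for it stays unknown.

Among the compounds shown here, two chain lengths make only a single step, so they cannot show whether the number would keep rising with a chain longer than that of compound 2 or would level off or fall, and they say nothing about still shorter chains. As far as these compounds go, it also remains open whether the tetrazole ring is needed at the end of the chain, or whether a carboxylic acid on the same chain would give a similar number.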